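Working notes: from compound 2 to compound 3

The compounds below may be only part of what the source reports. "The series", "measured", "known", "first", "only" and "open" are said of these compounds alone.

Measured so far:
compound 1 `S=C(Nc1ccccc1)N1N=C(c2ccc(Cl)cc2)CC1c1ccc2c(c1)OCCO2` – 195000 nM
compound 2 `FC(F)(F)c1ccc(C2=NN(C(=S)Nc3ccccc3)C(c3ccc4c(c3)OCCO4)C2)cc1` – 43500 nM

In a functional assay on A-375 cells (Homo sapiens) for antiproliferative activity, read by MTT assay, with a stated time of 48 h (on this read-out higher numbers stand for weaker inhibition of growth and lower numbers for stronger inhibition of growth), compound 2 gives 43500 nM, the lowest of the two numbers measured; the nearest is compound 1 with 195000 nM. Within the data shown here, the only step documented is the one from compound 1 to compound 2, a 4.5-fold lower number from compound 1 to compound 2 (0.65 log units; beyond the scatter), where trifluoromethyl replaced chloro on the same aromatic carbon.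

Compound 3 `S=C(Nc1ccccc1)N1N=C(c2ccc(OCc3ccccc3)cc2)CC1c1ccc2c(c1)OCCO2` is not yet measured. It differs from compound 2 by benzyloxy in place of trifluoromethyl on an aromatic carbon. Among the measured compounds shown here, the one measured step touches the same aromatic carbon, but it exchanged two small groups, whereas here a larger group enters, so it bears only loosely on the change at hand. For the measured compounds named here, no measured pair shows what a benzyloxy group does. The direction of the step in this assay is therefore open, and nothing beyond the scatter can be claimed with confidence.

Compound 3 is accordingly expected to land near compound 2, with an estimate of 35000 nM spanning 8000 nM to 150000 nM; the expected step is a 1.2-fold lower number from compound 2 to compound 3 (0.09 log units; within the scatter).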

Compound 3, concentration for 50% growth inhibition: 350 nM
The estimate for compound 3 lay 100-fold (2.00 log units) above the measured number, and the stated range ends above it.
By their numbers in this assay, from the lowest: compound 3; then compound 2; then compound 1.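

This position, on an aromatic carbon of a six-membered aromatic ring of carbon only and para to a large group, proves far more responsive in this assay than the exchange of chloro for trifluoromethyl suggested, which gave only a 4.5-fold lower number from compound 1 to compound 2 (0.65 log units; beyond the scatter) in the earlier pair. Benzyloxy gives a 120-fold lower number from compound 2 to compound 3 (2.09 log units; beyond the scatter) and, against chloro, a 560-fold lower number from compound 1 to compound 3 (2.75 log units; beyond the scatter) on the same carbon, so with the core unchanged, this one substituent can shift the number by a large margin across the three compounds. No measurement here bears on the origin of this large step.

The compounds shown do not separate the contributions of the oxygen, the added aromatic ring and the greater number of heavy atoms in benzyloxy, so a methoxy group, a directly attached phenoxy group or a longer chain such as phenethyloxy would be needed to tell which part of the group goes with the low number. Going by these compounds, it also remains open whether a chloro or methoxy group on the benzyl ring, or an amine at its outer end, would keep or extend the step seen with compound 3 in this assay on these cells.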